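Swapping the aryl group on a piperazine-like ring

This account rests on a few compounds, and the source may have more. Where it says the series, first, only, none or still open, it means among the compounds named here.

Of the compounds shown here, three sharing one core have been tested in an assay on CHO cells for displacement of a labelled ligand from adenosine receptor A1 (Homo sapiens), read by scintillation counting, with a stated time of 120 min, tested at 10 uM; on this read-out higher numbers stand for more inhibition at the one concentration tested (going by the name of the read-out) and lower numbers for less inhibition. Compound 1 `Nc1scc(CN2CCN(c3cccc(Cl)c3Cl)CC2)c1C(=O)c1ccc(Cl)cc1` gives 2% in this assay. Compound 2 `COc1ccc(N2CCN(Cc3csc(N)c3C(=O)c3ccc(Cl)cc3)CC2)cc1` gives 0%, and compound 3 `Nc1scc(CN2CCN(c3ccc(OC(F)(F)F)cc3)CC2)c1C(=O)c1ccc(Cl)cc1` gives 0%. Compound 2 shows the same number as compound 3 at the digits shown, and compound 1 lies within the scatter of both: the three values cannot be told apart. The steps confirm this, with a number 2 percentage points lower from compound 1 to compound 2 (within the scatter), a number 2 percentage points lower from compound 1 to compound 3 (within the scatter) and no change at the digits printed from compound 2 to compound 3 (within the scatter).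

Compound 4 `Nc1scc(CN2CCN(c3cccc(Cl)c3)CC2)c1C(=O)c1ccc(Cl)cc1` is not yet measured. It differs from compound 2 in one place: 3-chlorophenyl in place of 4-methoxyphenyl on an amine nitrogen in a ring. The measured steps that bear on this all change the same aromatic group on the ring nitrogen, and none of them moved the number beyond the scatter, so no shift beyond the scatter is expected here either. Compound 4 is therefore estimated to give 1%, within -6% and 10%. The expected step is a number 1 percentage points higher from compound 2 to compound 4 (within the scatter).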

Compound 4, a percentage reported as inhibition, at one concentration (the size of the read-out at that concentration, not a potency): 0%
Compound 4: middle estimate off by 1 percentage points, on the high side; the measured number falls inside the stated range.
By their numbers in this assay, from the lowest: compounds 2, 3, 4 and 1 (each within the scatter of the next).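

Putting 3-chlorophenyl on the ring nitrogen in this assay gives no change at the digits printed from compound 2 to compound 4 (within the scatter) and no change at the digits printed from compound 3 to compound 4 (within the scatter), so a chloro-substituted phenyl with no oxygen in its substituent reads the same as the two oxygen-bearing aryl groups. Hydrogen in place of one chloro, a far smaller edit than swapping the whole aryl group, gives a number 2 percentage points lower from compound 1 to compound 4 (within the scatter), so one chloro and two chloro groups on the phenyl cannot be told apart here. No measurement at hand explains why these four aryl groups read alike.

A benzyl or pyridyl group on the ring nitrogen could still behave differently from these phenyl groups. The same question remains for the rest of the shared core, such as an acetyl group on its amino group.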